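This account rests on a few compounds, and the source may have more. Where it says the series, first, only, none or still open, it means among the compounds named here.

Among the compounds with values here, in a functional assay on HCC827 cells (Homo sapiens) for cytotoxicity, read by MTT assay, with a stated time of 72 h (on this read-out higher numbers stand for weaker inhibition and lower numbers for stronger inhibition), compound 1 (`CC(C)n1c(Nc2ccccc2)nc2cnc(Nc3ccc(N4CCN(C)CC4)cc3)nc21`) gives 0.1 nM, the only true number among the measured compounds. Compound 2 (`Cc1cccc(Nc2nc3cnc(Nc4ccc(N5CCN(C)CC5)cc4)nc3n2C2CCCC2)c1`) reads < 0.01 nM, which is a limit of the assay and not a number. Compound 3 (`CN1CCN(c2ccc(Nc3ncc4nc(Nc5cccc(Cl)c5)n(C5CCCC5)c4n3)cc2)CC1`) reads < 0.01 nM, and this too is only a limit. Compound 3 therefore has no exact position, and it shares its reading with one other compound: the limit of < 0.01 nM in this assay, at which 2 of the 3 values shown sit.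

Compound 4 (`CN1CCN(c2ccc(Nc3ncc4nc(Nc5ccc(Br)cc5F)n(C5CCCC5)c4n3)cc2)CC1`) keeps the rest of compound 3 and carries 4-bromo-2-fluorophenyl in place of 3-chlorophenyl on a nitrogen on an aromatic ring. Within the data shown here, one measured step touches the same aromatic group, a step that the two limits leave unreadable from compound 2 to compound 3, with chloro in place of methyl on an aromatic carbon. That step has no readable size, so it offers no scale to carry over to the new group.

Any expectation in this assay is therefore loose. Compound 4 is expected to stay strong, with its upper range reaching towards compound 1 at 0.1 nM. The expected move, towards weaker inhibition if any shows at all, is an at least 2.0-fold higher number from compound 3 to compound 4 (0.30 log units; that floor lies within the scatter). Compound 4 is estimated at 0.02 nM, with an expected range from 0.004 nM to 0.2 nM.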

Compound 4, half-maximal inhibitory concentration: 2.3 nM
Compound 4: the middle estimate sits 120-fold (2.06 log units) below what was measured; the measured number lies above the stated range.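

In this assay, a change on a nitrogen on an aromatic ring proves able to move the read-out far: 4-bromo-2-fluorophenyl in place of 3-chlorophenyl gives an at least 230-fold higher number from compound 3 to compound 4 (2.36 log units; beyond the scatter), and the same group in place of 3-methylphenyl gives an at least 230-fold higher number from compound 2 to compound 4 (2.36 log units; beyond the scatter). Within the data shown here, the earlier compounds gave no readable size for any change on this aromatic group, so these two steps are the first to show that the group's substitution can matter well beyond the scatter. Both steps are floors and not exact sizes, because each starts from a value that is only a limit: the limit of < 0.01 nM in this assay, at which 2 of the 4 values shown sit.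

The compounds shown do not separate the bromo from the fluoro in 4-bromo-2-fluorophenyl, so it stays open whether one of them alone would give a step of this size. They also leave open how a methoxy group or an amine on this aromatic ring would read with the rest of compound 3 held fixed, and how far compound 2 and compound 3 truly lie from compound 4.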